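The compounds below may be only part of what the source reports. "The series", "measured", "known", "first", "only" and "open" are said of these compounds alone.

Measured so far:

compound 1, `Cc1ccc([S+]([O-])N2CCC[C@H]2COCCCCCC/C=C/c2ccc(-c3ccccc3)cc2)cc1`: >= 100000 nM
compound 2, `Cc1ccc([S+]([O-])N2CCC[C@H]2COCCCCCCCCC/C=C/c2ccc(-c3ccccc3)cc2)cc1`: > 100000 nM
compound 3, `O=CN1CCC[C@H]1COCCCCCC/C=C/c1ccc(-c2ccccc2)cc1`: 53300 nM

All three were tested in a functional assay on BXPC-3 cells (Homo sapiens) for inhibition, read by XTT assay, with a stated time of 72 h; on this read-out lower numbers stand for stronger inhibition and higher numbers for weaker inhibition. For compound 1 the value >= 100000 nM is a limit of the assay and not a number, as recorded in the limit of >= 100000 nM in this assay, at which 1 of the 3 values shown sits. For compound 2 the value > 100000 nM is likewise a limit, as recorded in the limit of > 100000 nM in this assay, at which 1 of the 3 values shown sits. Only compound 3, with 53300 nM in this assay, gives a number.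

Compound 1 and compound 3 differ in one place: a group of 2 heavy atoms (1 carbon, 1 oxygen; no ring) in place of a group of 9 heavy atoms (7 carbon, 1 oxygen, 1 sulfur; one six-membered aromatic ring of carbon only), on an amine nitrogen in a ring. This change gives an at least 1.8-fold lower number from compound 1 to compound 3 (0.27 log units; that floor lies within the scatter), so it cannot be read as more than a hint of stronger inhibition.

Compound 2 and compound 1 share the same groups at both ends but differ in the chain between them; that difference between the two cores is not broken down here. Compound 4, `O=CN1CCC[C@H]1COCCCCCCCCC/C=C/c1ccc(-c2ccccc2)cc1`, stands to compound 2 exactly as compound 3 stands to compound 1: a group of 2 heavy atoms (1 carbon, 1 oxygen; no ring) in place of a group of 9 heavy atoms (7 carbon, 1 oxygen, 1 sulfur; one six-membered aromatic ring of carbon only), on an amine nitrogen in a ring. The place is described in the same words for both pairs, so this is the same change.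

Because compound 2 sits at the limit of > 100000 nM in this assay, at which 1 of the 3 values shown sits, and the measured step of an at least 1.8-fold lower number from compound 1 to compound 3 (0.27 log units; that floor lies within the scatter) is itself only a floor, the step from compound 2 to compound 4 is expected to be of similar size, an at least 1.5-fold lower number from compound 2 to compound 4 (0.18 log units; that floor lies within the scatter), and may well end at a limit again. Compound 4 is accordingly estimated at 65000 nM in this assay, expected to lie between 25000 nM and 150000 nM.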

Compound 4, half-maximal inhibitory concentration: 66700 nM
For compound 4 the middle estimate is 1.0-fold (0.01 log units) below the measured one; the measured number falls inside the stated range.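

Putting formyl in place of the larger sulfur-containing group on the ring nitrogen gives, in this assay, an at least 1.4-fold lower number from compound 2 to compound 4 (0.17 log units; that floor lies within the scatter). Set beside the earlier case, the same swap points the same way on both cores, which fits the idea that it can be carried from one core to the other, yet neither step amounts to more than a hint: the same change on two cores in this assay, an at least 1.8-fold lower number (0.27 log units; that floor lies within the scatter) from compound 1 to compound 3 and an at least 1.4-fold lower number (0.17 log units; that floor lies within the scatter) from compound 2 to compound 4; the limit leaves it open whether they differ. From the compounds shown here alone, the true size of the change stays unknown on either core, and compound 2, the starting point of the new step, gives only a limit and no number: the limit of > 100000 nM in this assay, at which 1 of the 4 values shown sits.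

The compounds shown leave open what other groups on the ring nitrogen would give, such as acetyl or a plain alkyl amine, and whether any of them would move the number further than formyl does. They also leave open what a shorter chain or a still longer chain would give with formyl kept in place, and so whether chain length matters at all in this series.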